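The source may report more compounds than this note shows. Statements on the series, on what has been measured and on what is new or still open speak of the compounds shown alone.

In an ADME assay on L1210/0 cells (Mus musculus) for cytotoxicity, with a stated time of 48 h (on this read-out higher numbers stand for weaker inhibition and lower numbers for stronger inhibition), compound 1 `Nc1ncnc2c1nnn2C[C@H]1CCC[C@H]1CO` gives > 200000 nM, which is a limit of the assay and not a number. Compound 2 `CC1(C)C(CO)CC1Cn1cnc2c(N)nc(N)nc21` gives > 200000 nM, again a limit and not a number. From the compounds shown here alone, compound 2 therefore stands at the limit of > 200000 nM in this assay, at which 2 of the 2 values shown sit, so its true strength in this assay remains unknown.

Compound 3 `CC1(C)C(CO)CC1Cn1cnc2c(Cl)nc(N)nc21` differs from compound 2 in one place: chloro in place of amino on an aromatic carbon. Going by the values given here, no measured pair of compounds shows what a change of this kind does here, so any forecast is uncertain. A modest shift towards stronger inhibition is expected, and another limit is quite possible. The expected change is an at least 1.6-fold lower number from compound 2 to compound 3 (0.22 log units; that floor lies within the scatter). In this assay, the estimate for compound 3 is 120000 nM, with an expected range from 30000 nM to 300000 nM.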

Compound 3, half-maximal inhibitory concentration: > 200000 nM
Compound 3 gave a limit, no number (the forecaster's own chance of this, stated with the estimate: 60%); at least 1.6-fold (0.22 log units) between middle value and limit.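

Compound 2 and compound 3 both give a limit of the assay and not a number, so no step can be read from the change of amino to chloro: the limit of > 200000 nM in this assay, at which 3 of the 3 values shown sit.

The compounds shown leave open how strongly any of them truly acts in this assay.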